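This account rests on a few compounds, and the source may have more. Where it says the series, first, only, none or still open, it means among the compounds named here.

In a functional assay on HeLa cells (Homo sapiens) for antiproliferative activity, read by MTT assay, with a stated time of 48 h (on this read-out higher numbers stand for weaker inhibition and lower numbers for stronger inhibition), compound 1 `Cc1ccc(-c2nc(N)c3cc(Cl)ccc3n2)cc1` gives 3.56 ug/mL. Among the measured compounds shown here, compound 2 `Cc1ccc(-c2nc(NC(=O)c3ccccc3)c3cc(Cl)ccc3n2)cc1` gives 16.2 ug/mL, the higher of the two numbers measured so far. For the measured compounds named here, only one measured step exists: a 4.6-fold higher number from compound 1 to compound 2 (0.66 log units; beyond the scatter). Compound 3 `CSc1nc(-c2ccc(C)cc2)nc2ccc(Cl)cc12` differs from compound 2 by methylsulfanyl in place of benzamido on an aromatic carbon. Going by the values given here, that step added a benzoyl; here the whole benzamido leaves, and no measured step covers methylsulfanyl, so the expectation leans on a single step and stays uncertain. Compound 3 is expected to give about 6 ug/mL, with a likely range from 2 ug/mL to 18 ug/mL. The expected step is a 2.7-fold lower number from compound 2 to compound 3 (0.43 log units; beyond the scatter).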

Compound 3, half-maximal inhibitory concentration: 14.7 ug/mL
Beside the measured number, compound 3's estimate is 2.5-fold (0.39 log units) below it; low and high end bracket the measured number.
By their numbers in this assay, from the lowest: compound 1; then compounds 3 and 2 (each within the scatter of the next).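

In this assay, replacing benzamido with the much smaller methylsulfanyl on this aromatic carbon gives a 1.1-fold lower number from compound 2 to compound 3 (0.04 log units; within the scatter), so the ringed benzamido group is not needed to reach this level. Methylsulfanyl in place of amino gives a 4.1-fold higher number from compound 1 to compound 3 (0.62 log units; beyond the scatter), so among these three compounds, the amino group of compound 1 gives the lowest number, and two quite different replacements both give higher ones. No measurement shown here explains this. Going by these compounds, it remains open whether a methylamino or methoxy group at this carbon would give a number closer to compound 1 or to compound 3.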